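A Larger Substituent Tested on the Core of Compound 1

The source may report more compounds than this note shows. Statements on the series, on what has been measured and on what is new or still open speak of the compounds shown alone.

Compound 1 `COC(=O)/C=C/c1cccc(N(Cc2ccccc2)C(=O)C2CCCCC2)c1` was examined in an assay on isolated protein with Bile acid receptor (Homo sapiens) as the target; on this read-out higher numbers stand for an effect only at larger amounts of compound and lower numbers for an effect already at smaller amounts. In this assay compound 1 gives > 1000 nM, which is a limit of the assay and not a number. Compound 2 `COC(=O)/C=C/c1cccc(N(Cc2ccccc2Br)C(=O)C2CCCCC2)c1` carries bromo in place of hydrogen on an aromatic carbon; in this assay compound 2 gives > 1000 nM, again a limit. Compound 3 `COC(=O)/C=C/c1cccc(N(Cc2cccc(OC)c2)C(=O)C2CCCCC2)c1` carries methoxy in place of hydrogen on an aromatic carbon; in this assay compound 3 gives > 1000 nM, also a limit. The step that the two limits leave unreadable from compound 1 to compound 2 and the step that the two limits leave unreadable from compound 1 to compound 3 cannot be read, and the same holds for the step that the two limits leave unreadable from compound 2 to compound 3, because the limit of > 1000 nM in this assay, at which 3 of the 3 values shown sit, is where all three values stand.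

Compound 4 `COC(=O)/C=C/c1cccc(N(Cc2ccc(/C=C/c3ccc(F)cc3)cc2)C(=O)C2CCCCC2)c1` differs from compound 1 in one place: 2-(4-fluorophenyl)ethenyl in place of hydrogen on an aromatic carbon. Among the measured compounds shown here, none of the measured steps changes an aromatic carbon in this way, and none of them has a readable size, so no measured step shows how far this change moves the value or in which direction. The estimate for compound 4 in this assay is therefore 2000 nM, with a range from 200 nM to 20000 nM. This estimate means an expected step that the limit leaves unreadable from compound 1 to compound 4.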

Compound 4, half-maximal effective concentration: 185 nM
For compound 4 the middle estimate is 11-fold (1.03 log units) above the measured one, and the stated range ends above it.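

In this assay, 2-(4-fluorophenyl)ethenyl in place of hydrogen gives an at least 5.4-fold lower number from compound 1 to compound 4 (0.73 log units; beyond the scatter), the only readable step in this small set, and compound 4 is the only compound shown with a value that is a number and not a limit. The change sits on an aromatic carbon, para to a large group, and it brings 9 heavy atoms, one more six-membered aromatic ring and one double bond outside aromatic rings, so this place on the core of compound 1 tolerates a large addition and the value moves to a lower number. The earlier compounds could not show any such movement, and the steps among compound 1, compound 2 and compound 3 cannot be read because all three stop at the same limit: the limit of > 1000 nM in this assay, at which 3 of the 4 values shown sit.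

Compound 4 adds the whole group at once, which leaves open how much of the step belongs to the fluorine, the double bond or the added ring. Also open, going by these compounds, is what a smaller group at the same place would do, such as a plain phenyl or a short chain, or a more different one such as an amine or a carboxylic acid.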